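A Fluorophenyl Swap Carried onto a Second Core

The source may hold more compounds than are shown below. What is called first, only, known or untested is meant among the compounds shown, and "the series" means these compounds.

Compound 1 `O=C1/C(=C/c2ccccc2F)CN(Cc2cn(Cc3ccccc3F)nn2)C/C1=C\c1ccccc1F` gives 6500 nM in a functional assay on 4T1 cells (Mus musculus) for cytotoxicity, read by MTT assay, with a stated time of 24 h; a higher number here means a weaker inhibitor, a lower number a stronger inhibitor.
Compound 2 `O=C1/C(=C/c2ccccc2F)CN(Cc2cn(Cc3cccc(Cl)c3)nn2)C/C1=C\c1ccccc1F` gives 6100 nM.
Compound 3 `Cc1ccc(/C=C2\CN(Cc3cn(Cc4cccc(Cl)c4)nn3)C/C(=C\c3ccc(C)cc3)C2=O)cc1` gives 29300 nM.

Compound 1 and compound 2 share one core; compound 3 rests on another, and the difference between the two cores is not broken down here. Compound 3 stands highest of the three, and its gaps to compound 1 and to compound 2 are both beyond the scatter. Within the first core, the change 2-fluorophenyl in place of 3-chlorophenyl on a saturated chain carbon bound to an aromatic nitrogen produced a 1.1-fold higher number from compound 2 to compound 1 (0.03 log units; within the scatter). Compound 4 `Cc1ccc(/C=C2\CN(Cc3cn(Cc4ccccc4F)nn3)C/C(=C\c3ccc(C)cc3)C2=O)cc1` is the unmeasured partner of compound 3, carrying the change (2-fluorophenyl in place of 3-chlorophenyl on a saturated chain carbon bound to an aromatic nitrogen), the same change at the same place. Because a 1.1-fold higher number from compound 2 to compound 1 (0.03 log units; within the scatter) stayed within the scatter, the expected step is a 1.1-fold higher number from compound 3 to compound 4 (0.02 log units; within the scatter). Compound 4 is therefore estimated at 31000 nM, with a likely range from 13000 nM to 75000 nM.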

Compound 4, half-maximal inhibitory concentration: 18000 nM
Compound 4: middle estimate off by 1.7-fold (0.24 log units), on the high side; the range from low to high includes it.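

Replacing 3-chlorobenzyl with 2-fluorobenzyl on the second core gives a 1.6-fold lower number from compound 3 to compound 4 (0.21 log units; within the scatter), so in this assay this step is too small to separate from the noise of repeated measurements. Set beside the step on the first core, it shows no difference between the two cores: the same change on two cores in this assay, a 1.1-fold higher number (0.03 log units; within the scatter) from compound 2 to compound 1 and a 1.6-fold lower number (0.21 log units; within the scatter) from compound 3 to compound 4, 1.7-fold (0.24 log units) apart, within the scatter of two such steps On these two cores, then, the change carries over with no readable effect, but that does not show that it would behave the same way on a third core, and steps this small give it no direction.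

As far as these compounds go, it remains open whether a different group in place of the 2-fluorobenzyl group, such as an amine, a carboxylic acid or a longer chain, would give a step beyond the scatter.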